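Methyl in place of chloro: expected cytotoxicity of compound 3

This account rests on a few compounds, and the source may have more. Where it says the series, first, only, none or still open, it means among the compounds named here.

compound 1 `CC(C)CC1(Cc2ccccc2)OS(=O)(=O)C=C1OCc1ccccc1`: 102000 nM
compound 2 `CCC1(Cc2ccccc2)OS(=O)(=O)C=C1OCc1ccc(Cl)cc1`: > 200000 nM

In an ADME assay on HEL cells (Homo sapiens) for cytotoxicity, with a stated time of 3 days (on this read-out higher numbers stand for lower toxicity in this test and lower numbers for higher toxicity in this test), compound 1 gives 102000 nM. For compound 2 the result is only a limit, > 200000 nM, and no number. Compound 2 thus sits at the limit of > 200000 nM in this assay, at which 1 of the 2 values shown sits.

Compound 3 `CCC1(Cc2ccccc2)OS(=O)(=O)C=C1OCc1ccc(C)cc1` differs from compound 2 by methyl in place of chloro on an aromatic carbon. Within the data shown here, no step between measured compounds is known, so the effect of this change in this assay cannot be read from the data; no shift beyond the scatter is expected. Compound 3 is estimated at 200000 nM, within 80000 nM to 400000 nM. The expected step is a number no higher from compound 2 to compound 3 (the limit leaves the size open), essentially none.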

Compound 3, half-maximal cytotoxic concentration: 41500 nM
Compound 3: middle estimate off by 4.8-fold (0.68 log units), on the high side; the measured number lies below the stated range.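

In this assay, methyl in place of chloro, para to a large group, gives an at least 4.8-fold lower number from compound 2 to compound 3 (0.68 log units; beyond the scatter), so this position responds to the change. Only one heavy atom is exchanged, with no hydrogen-bond donor, acceptor or net charge involved, yet the read-out moves towards higher toxicity in this test. Compound 2 stands at a limit, so the full size of the step stays open: the limit of > 200000 nM in this assay, at which 1 of the 3 values shown sits.

From the compounds shown here alone, whether an amine, a carboxylic acid or a longer chain at this position would follow methyl or chloro remains open. So does whether the same exchange would act alike on the core of compound 1.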